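Extending the thioether chain of a galloyl cysteine ester

This account rests on a few compounds, and the source may have more. Where it says the series, first, only, none or still open, it means among the compounds named here.

The series concerns four cysteine methyl ester derivatives carrying an unsaturated thioether chain. Compound 1 `C=CCCSC[C@H](N)C(=O)OC` and compound 2 `C=CCCCSC[C@H](N)C(=O)OC` have a free amine; compound 3 `C=CCCSC[C@H](NC(=O)c1cc(O)c(O)c(O)c1)C(=O)OC` and compound 4 `C=CCCCSC[C@H](NC(=O)c1cc(O)c(O)c(O)c1)C(=O)OC` carry a galloyl amide on the nitrogen. In an assay on RAW264.7 cells for antagonist activity at Toll-like receptor 2 (Mus musculus), read by Griess assay, with a stated time of 24 h (on this read-out higher numbers stand for weaker inhibition and lower numbers for stronger inhibition), compound 1 gives 45500 nM and compound 2 gives 31300 nM. The two differ only by allyl in place of vinyl on a saturated chain carbon, two bonds along the chain from a sulfur, and this change gave a 1.5-fold lower number from compound 1 to compound 2 (0.16 log units; within the scatter).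

Compound 3, with the galloyl amide, gives 57800 nM in this assay. How the core of compound 3 differs from the core of compound 1 is not broken down here. Compound 4 stands to compound 3 as compound 2 stands to compound 1: the difference is allyl in place of vinyl on a saturated chain carbon, two bonds along the chain from a sulfur, and since the two place lines read alike, this is the same change carried onto the galloyl amide core.

Within the data shown here, the expectation for compound 4 rests on the single earlier instance of this change, the step of a 1.5-fold lower number from compound 1 to compound 2 (0.16 log units; within the scatter) between compound 1 and compound 2, and on the starting point set by compound 3, whose value is 57800 nM. On that basis compound 4 is expected to show the step of a 1.5-fold lower number from compound 3 to compound 4 (0.17 log units; within the scatter) in this assay, a step that would stay within the usual scatter. Compound 4 is therefore estimated at 39000 nM in this assay, with a likely range from 20000 nM to 80000 nM, pending the actual measurement.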

Compound 4, half-maximal inhibitory concentration: 39200 nM
Compound 4: middle estimate off by 1.0-fold (0.00 log units), on the low side, within the range that was stated.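

In this assay, the change from but-3-en-1-yl to pent-4-en-1-yl on the thioether of the galloyl amide core gave a 1.5-fold lower number from compound 3 to compound 4 (0.17 log units; within the scatter), so the step seen with the free amine also appears on this second core. Set side by side, the two instances agree, and the change reads the same with the free amine and with the galloyl amide: the same change on two cores in this assay, a 1.5-fold lower number (0.16 log units; within the scatter) from compound 1 to compound 2 and a 1.5-fold lower number (0.17 log units; within the scatter) from compound 3 to compound 4, 1.0-fold (0.01 log units) apart, within the scatter of two such steps

Among these compounds, this agreement does not show that the extra chain carbon matters for inhibition, since each step lies within the scatter and neither can be told apart from no change at all; what carries from one core to the other is the absence of a step beyond the scatter, and only two cores in a single assay support even that.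

The compounds shown leave open whether a longer chain than pent-4-en-1-yl, or a saturated propyl or butyl chain in place of the terminal alkene, would move the number beyond the scatter on either core. They also leave open how a free carboxylic acid in place of the methyl ester, or a benzoyl amide without the three hydroxyl groups of the galloyl amide, would read in this assay.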